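Nitro in Place of Amino: What to Expect for Compound 4

A few compounds are considered here, and "the series" means these few. Any claim that something is new, unique, unknown or untested is made for them only; others in the source may bear on it.

Compound 1, `Cc1cc(S(=O)(=O)N2C(=O)N[C@@H](c3ccccc3)C2C)ccc1NC(=O)c1ccc([N+](=O)[O-])cc1`: in a functional assay on NCI-H460 cells (Homo sapiens) for cytotoxicity, read by MTT assay (a lower number here means a stronger inhibitor, a higher number a weaker inhibitor), compound 1 gives > 10000 nM, a limit of the assay.
Compound 2, `CCOC(=O)Nc1ccc(S(=O)(=O)N2C(=O)N[C@@H](c3ccccc3)C2C)cc1Cl`: compound 2 gives 6000 nM.
Compound 3, `CC1[C@H](c2ccccc2)NC(=O)N1S(=O)(=O)c1ccc(NC(=O)c2ccc(N)cc2)c(Cl)c1`: compound 3 gives > 10000 nM, again a limit.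

Compound 3 thus stands at the limit of this assay, where two of the three measured values sit (the limit of > 10000 nM in this assay, at which 2 of the 3 values shown sit). Among the measured compounds shown here, the only measured step touching it, an at least 1.6-fold higher number from compound 2 to compound 3 (0.22 log units; that floor lies within the scatter), brings the 4-aminophenyl group onto a carbonyl carbon and ends at that limit. Compound 4, `CC1[C@H](c2ccccc2)NC(=O)N1S(=O)(=O)c1ccc(NC(=O)c2ccc([N+](=O)[O-])cc2)c(Cl)c1`, differs from compound 3 by nitro in place of amino on an aromatic carbon. For the measured compounds named here, no measured step covers this exchange itself; compound 1, which also bears a (4-nitrophenyl)carbonyl, sits at the limit as well. Compound 4 is therefore expected to remain at or past the limit, the estimated step that the limit leaves unreadable from compound 3 to compound 4 showing no direction beyond the scatter. The estimate for compound 4 is 15000 nM, between 5000 nM and 45000 nM.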

Compound 4, half-maximal inhibitory concentration: > 10000 nM
Compound 4 was reported as a limit; the forecaster's own chance of this, stated with the estimate: 75%; the middle value does not contradict the limit.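

In this assay compound 4 gives > 10000 nM, a limit of the assay, so with nitro in place of amino on this aromatic carbon, para to a large group, the 4-nitrophenyl compound yields no number, just as the 4-aminophenyl compound 3 does. Among the compounds shown here, the steps to compound 4 from compound 3 and from compound 1 cannot be read, and the one readable step is an at least 1.6-fold higher number from compound 2 to compound 4 (0.22 log units; that floor lies within the scatter). The limit now holds most of the set: the limit of > 10000 nM in this assay, at which 3 of the 4 values shown sit.

On these data alone, whether nitro and amino differ at all here stays open. So does whether a methoxy or a carboxylic acid at this place would give a readable value.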